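A few compounds are considered here, and "the series" means these few. Any claim that something is new, unique, unknown or untested is made for them only; others in the source may bear on it.

In a functional assay on ECa-109 cells (Homo sapiens) for antiproliferative activity, read by MTT assay, with a stated time of 72 h (a higher number here means a weaker inhibitor, a lower number a stronger inhibitor), compound 2 (`CCCSc1nc(N/N=C(\C)c2ccc(OC)cc2)c2nnn(Cc3ccccc3)c2n1`) gives > 64000 nM as a limit of the assay, not a number. Compound 2 thus stands at the limit of > 64000 nM in this assay, at which 1 of the 3 values shown sits, and has no exact place among the values. In this assay compound 1 (`CCCSc1nc(N/N=C(\C)c2ccccc2O)c2nnn(Cc3ccc(Cl)cc3)c2n1`) gives 11200 nM and compound 3 (`COc1cc(/C=N/Nc2nc(SCc3ccccc3)nc3c2nnn3Cc2ccccc2)cc(OC)c1OC`) gives 4400 nM as numbers. Compound 4 (`CCCSc1nc(N/N=C(\C)c2ccc(Br)cc2)c2nnn(Cc3ccccc3)c2n1`) carries bromo in place of methoxy on an aromatic carbon, para to a large group. For the measured compounds named here, no measured pair isolates this change. A modest move towards stronger inhibition in this assay is expected, and a reading at the limit remains possible. The estimated step of an at least 1.6-fold lower number from compound 2 to compound 4 (0.20 log units; that floor lies within the scatter) is expected to be small. For compound 4 the expected value is 40000 nM with an estimated range from 12000 nM to 64000 nM in this series.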

Compound 4, half-maximal inhibitory concentration: 4670 nM
For compound 4 the middle estimate is 8.6-fold (0.93 log units) above the measured one, outside the stated range (below it).
By their numbers in this assay, from the lowest: compounds 3 and 4 (each within the scatter of the next); then compound 1. At a limit, above all of these: compound 2.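

For the compounds shown here, replacing 4-methoxyphenyl with 4-bromophenyl provides the first comparison that differs in one place. In this assay the change gives an at least 13-fold lower number from compound 2 to compound 4 (1.13 log units; beyond the scatter) and shows that this substituent, para to a large group, can move the read-out well beyond the scatter. The step is only a floor because compound 2 is a limit of the assay, not a number: the limit of > 64000 nM in this assay, at which 1 of the 4 values shown sits.

Going by these compounds, only methoxy and bromo are compared at this carbon, so it remains open whether bromo itself matters or the loss of methoxy is enough. An amine or a carboxylic acid here would help separate the two.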